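From dimethylamino to cyclohexylamino on a carbonyl carbon

The source may report more compounds than this note shows. Statements on the series, on what has been measured and on what is new or still open speak of the compounds shown alone.

Measured in a functional assay on the whole organism with Mus musculus as the target (on this read-out higher numbers stand for an effect only at larger amounts of compound and lower numbers for an effect already at smaller amounts), so far:
Compound 1 `NC(=O)/C=C/c1cccc(C(F)(F)F)c1` (54.5 mg/kg)
Compound 2 `O=C(/C=C/c1cccc(C(F)(F)F)c1)NCCO` (186 mg/kg)
Compound 3 `CN(C)C(=O)CCC(=O)c1cccc(C(F)(F)F)c1` (> 50 mg/kg)

Compound 3 stands at a limit (> 50 mg/kg) and has no exact number. Compound 4 `O=C(CCC(=O)c1cccc(C(F)(F)F)c1)NC1CCCCC1` carries cyclohexylamino in place of dimethylamino on a carbonyl carbon. For the measured compounds named here, only one measured step bears on this change, and only loosely: 2-hydroxyethyl in place of hydrogen on an amide-type nitrogen gave a 3.4-fold higher number from compound 1 to compound 2 (0.53 log units; beyond the scatter) as a modest step. A step of similar modest size toward a higher number is therefore expected in this assay, although this direction rests on that single step. The expected step is a step that the limit leaves unreadable from compound 3 to compound 4 here. Compound 4 is estimated at 100 mg/kg, with the expected range running from 35 mg/kg to 300 mg/kg.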

Compound 4, dose for half-maximal effect: > 200 mg/kg
Compound 4: no number, only a limit; the forecaster's own chance of this, stated with the estimate: 35%; middle value at least 2.0-fold (0.30 log units) away from the limit.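

In this assay, compound 3 and compound 4 both stand only at limits, and no step can be read between them. The compounds shown leave open how cyclohexylamino truly compares with dimethylamino on this carbonyl carbon.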